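Swapping Halogens on the Amide-Linked Phenyl Ring

The source may report more compounds than this note shows. Statements on the series, on what has been measured and on what is new or still open speak of the compounds shown alone.

Compound 1 `CCOC(=O)C1=Cc2ccccc2OC1(OCc1cn(CC(=O)Nc2cccc(Cl)c2)nn1)C(F)(F)F` gives 10100 nM in a functional assay on DU-145 cells (Homo sapiens) for inhibition, read by MTT assay, with a stated time of 24 h; on this read-out lower numbers stand for stronger inhibition and higher numbers for weaker inhibition. Compound 2 `CCOC(=O)C1=Cc2ccccc2OC1(OCc1cn(CC(=O)Nc2ccccc2Br)nn1)C(F)(F)F` gives only a limit in this assay, namely > 150000 nM.

Compound 2 thus stands at the weak end of the two results, where no number but only a limit is known. The change to compound 3 `CCOC(=O)C1=Cc2ccccc2OC1(OCc1cn(CC(=O)Nc2ccc(I)cc2Cl)nn1)C(F)(F)F` is 2-chloro-4-iodophenyl in place of 2-bromophenyl on an amide-type nitrogen. Among the compounds with values here, the single measured step that bears on this position is an at least 14-fold higher number from compound 1 to compound 2 (1.17 log units; beyond the scatter), which shows that altering the halogen on this phenyl ring can shift the number markedly. Within the data shown here, the 2-chloro-4-iodophenyl of compound 3 carries two halogens where the 2-bromophenyl of compound 2 carries one, and no measured step shows the effect of such a second halogen, so the outcome is uncertain. Compound 3 is therefore expected to give about 60000 nM, with a range from 10000 nM to 200000 nM. That expectation means a step of an at least 2.5-fold lower number from compound 2 to compound 3 (0.39 log units; beyond the scatter), with a real chance that only a limit is reported again.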

Compound 3, half-maximal inhibitory concentration: 24400 nM
Beside the measured number, compound 3's estimate is 2.5-fold (0.39 log units) above it; low and high end bracket the measured number.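

The 2-chloro-4-iodophenyl group shows that a ring with two halogens can keep measurable inhibition of these cells, and this change gives an at least 6.1-fold lower number from compound 2 to compound 3 (0.78 log units; beyond the scatter). Compound 2 is known only through a limit, so that step gives a minimum size and not an exact one: the limit of > 150000 nM in this assay, at which 1 of the 3 values shown sits. The new group still does not match the 3-chlorophenyl group, with a 2.4-fold higher number from compound 1 to compound 3 (0.38 log units; beyond the scatter), which leaves compound 1 the strongest of the three.

As far as these compounds go, it remains open which halogen of compound 3 matters more, and whether a 2-chlorophenyl or a 4-iodophenyl group alone would give a similar number. From the compounds shown here alone, it is equally open how a plain phenyl ring, or one carrying an amine or a carboxylic acid, would compare with these halogenated rings.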